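A few compounds are considered here, and "the series" means these few. Any claim that something is new, unique, unknown or untested is made for them only; others in the source may bear on it.

Of the compounds shown here, three that share one core have been measured in an ADME assay on microsomes from liver (Rattus norvegicus) for metabolic stability; a lower number here means slower removal, a higher number faster removal of the compound. Compound 1 `CNc1nc(NC)nc(NC2(C#N)CCCCC2)n1` gives 210 mL/min/kg, and compound 3 `CNc1nc(NC2(C#N)CCCCC2)nc(OC)n1` gives 196 mL/min/kg, so these two numbers lie within the usual scatter of each other. Compound 2 `CNc1nc(NC2(C#N)CCCCC2)nc(N2CCCC2)n1` reads > 276 mL/min/kg, which is a limit of the assay and not an exact number. For the measured compounds named here, compound 3 therefore stands level with compound 1, the only other compound with an exact number.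

Compound 4 `CNc1nc(NC2(C#N)CCCCC2)nc(-n2cnc(C)n2)n1` changes one group of compound 3, with 3-methyl-1H-1,2,4-triazol-1-yl in place of methoxy on an aromatic carbon. Three measured steps swap a group at this same place. Methoxy in place of methylamino gave a 1.1-fold lower number from compound 1 to compound 3 (0.03 log units; within the scatter). Pyrrolidin-1-yl in place of methylamino gave an at least 1.3-fold higher number from compound 1 to compound 2 (0.11 log units; that floor lies within the scatter), and methoxy in place of pyrrolidin-1-yl gave an at least 1.4-fold lower number from compound 2 to compound 3 (0.14 log units; that floor lies within the scatter). None of these steps goes beyond the scatter, although two of them are only floors. None of the three compounds carries the incoming group, so they are only a loose guide.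

No step beyond the scatter is therefore expected in this assay, starting from compound 3 at 196 mL/min/kg. The expected step is a 1.0-fold lower number from compound 3 to compound 4 (0.01 log units; within the scatter). For compound 4 the estimate is 190 mL/min/kg, with an expected range from 100 mL/min/kg to 280 mL/min/kg.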

Compound 4, clearance: > 276 mL/min/kg
Compound 4: only a limit was reported; the forecaster's own chance of this, stated with the estimate: 20%; middle value at least 1.4-fold (0.16 log units) away from the limit.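

In this assay compound 4 gives > 276 mL/min/kg, which is a limit of the assay and not an exact number. Placing 3-methyl-1H-1,2,4-triazol-1-yl at this position gives an at least 1.4-fold higher number from compound 3 to compound 4 (0.14 log units; that floor lies within the scatter), and replacing methylamino with it gives an at least 1.3-fold higher number from compound 1 to compound 4 (0.11 log units; that floor lies within the scatter), so neither floor shows a real change, although the true steps could be larger. Compound 2 and compound 4 both stop at the same limit, so the step between them cannot be read, and the position now has two ring-bearing groups, one saturated and one aromatic, that give no exact number, while the methylamino of compound 1 and the methoxy of compound 3 do:  the limit of > 276 mL/min/kg in this assay, at which 2 of the 4 values shown sit.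

With only floors inside the scatter, these four compounds leave open whether a ring at this position truly means faster removal, and how far beyond the limit compound 2 and compound 4 lie. Going by these compounds, how a plain amine, a hydroxyl group or a morpholine ring would read at this place also remains open, and any of these could show whether an exact number below the limit can be reached with a different group.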